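Compound 3 to compound 4: tert-butyl replaced by hydrogen

This account rests on a few compounds, and the source may have more. Where it says the series, first, only, none or still open, it means among the compounds named here.

Measured in a functional assay on A549 cells (Homo sapiens) for antiproliferative activity, read by MTT assay, with a stated time of 72 h (a higher number here means a weaker inhibitor, a lower number a stronger inhibitor), so far:
Compound 1, `O=C1O/C(=C\Cn2cc(-c3ccc(Br)cc3)nn2)C(OCc2ccccc2)=C1OCc1ccccc1`: compound 1 gives > 100000 nM, which is a limit of the assay.
Compound 2, `O=C1O/C(=C\Cn2cc(-c3cc(C(F)(F)F)cc(C(F)(F)F)c3)nn2)C(OCc2ccccc2)=C1OCc1ccccc1`: compound 2 gives > 100000 nM, also a limit of the assay.
Compound 3, `CC(C)(C)c1cn(C[C@H](O)[C@H]2OC(=O)C(OCc3ccccc3)=C2OCc2ccccc2)nn1`: compound 3 gives 34000 nM.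

Within the data shown here, compound 3 therefore stands as the only measured number in this assay; the other two compounds sit at the limit of > 100000 nM in this assay, at which 2 of the 3 values shown sit. Among the measured compounds shown here, no pair among the three differs in a single place, so no measured step is available to guide what follows.

Compound 4, `O=C1O[C@H]([C@@H](O)Cn2ccnn2)C(OCc2ccccc2)=C1OCc1ccccc1`, differs from compound 3 in one place: hydrogen in place of tert-butyl on an aromatic carbon. With nothing measured on either side of this change, the expectation rests on the change alone. The step from compound 3 to compound 4 in this assay is expected to be a 2.4-fold higher number from compound 3 to compound 4 (0.37 log units; beyond the scatter), in the direction of weaker inhibition, and large enough that it may lie beyond the usual scatter. Compound 4 is accordingly estimated at 80000 nM, with a range from 25000 nM to 300000 nM, and with a real chance that this assay returns only a limit rather than a number.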

Compound 4, half-maximal inhibitory concentration: > 100000 nM
Compound 4 was reported as a limit (the forecaster's own chance of this, stated with the estimate: 45%); middle value at least 1.2-fold (0.09 log units) from the limit.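

Among these compounds, this is the first step that can be read in this assay, and it concerns the aromatic carbon of the five-membered aromatic ring: with hydrogen in place of tert-butyl, the change gives an at least 2.9-fold higher number from compound 3 to compound 4 (0.46 log units; beyond the scatter). Among the two compounds that differ only here, a measurable number is therefore seen only with the tert-butyl in place. Compound 4 is reported only as a limit, so the step marks a lower bound and not a full size: the limit of > 100000 nM in this assay, at which 3 of the 4 values shown sit.

The compounds shown leave open whether a smaller alkyl group such as methyl, or a ring such as cyclohexyl, at this carbon would give a number like that of compound 3 or a lower one. They also leave open how an amine or a longer alkyl chain in the same place would read.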